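A Second Methyl on the Weaker Core

The compounds below may be only part of what the source reports. "The series", "measured", "known", "first", "only" and "open" are said of these compounds alone.

Compound 1 `Cc1ccnc2nc(-c3cccc(Cl)c3)cc(O)c12` and compound 2 `Cc1cc(C)c2c(O)cc(-c3cccc(Cl)c3)nc2n1` share a core and differ by methyl in place of hydrogen on an aromatic carbon. In a functional assay on MDA-MB-435 cells (Homo sapiens) for antiproliferative activity (on this read-out lower numbers stand for stronger inhibition of growth and higher numbers for weaker inhibition of growth), compound 1 gives < 10 nM, which is a limit of the assay rather than a number. In this assay compound 2 gives 13.2 nM. The step of an at least 1.3-fold higher number from compound 1 to compound 2 (0.12 log units; that floor lies within the scatter) is only a floor because compound 1 sits at the limit of < 10 nM in this assay, at which 1 of the 3 values shown sits.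

Compound 3 `Cc1ccc2c(O)cc(-c3ccc4ccccc4c3)nc2n1` carries a different core; the difference between the two cores is not broken down here. In this assay compound 3 gives 1580 nM, the highest of the two numbers reported. Compound 4 `Cc1cc(C)c2c(O)cc(-c3ccc4ccccc4c3)nc2n1` is not yet measured and differs from compound 3 by methyl in place of hydrogen on an aromatic carbon. This is the same kind of change as that from compound 1 to compound 2, though the place differs: in compound 2 the methyl enters next to the ring nitrogen and para to a fused ring, whereas in compound 4 it enters ortho to a fused ring and opposite the ring nitrogen.

Since the earlier step was small, compound 4 is expected to move by about a 1.4-fold higher number from compound 3 to compound 4 (0.14 log units; within the scatter), resting on compound 3 at 1580 nM. Compound 4 is therefore estimated at 2200 nM, most likely between 700 nM and 7000 nM.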

Compound 4, concentration for 50% growth inhibition: 2950 nM
Compound 4: the middle estimate sits 1.3-fold (0.13 log units) below what was measured; the range from low to high includes it.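

Placing a methyl where a hydrogen stood on the core of compound 3 gives a 1.9-fold higher number from compound 3 to compound 4 (0.27 log units; within the scatter), so in this assay compound 3 and compound 4 cannot be told apart. On the core of compound 1 the same change can be read only as a floor, and the true step could be larger, so the data do not show that the change carries over from one core to the other with the same size, nor that it does not: the same change on two cores in this assay, an at least 1.3-fold higher number (0.12 log units; that floor lies within the scatter) from compound 1 to compound 2 and a 1.9-fold higher number (0.27 log units; within the scatter) from compound 3 to compound 4; the limit leaves it open whether they differ. Compound 1 stands at a limit of the assay, not at a number, and a compound with a measured value in its place would be needed to settle the comparison: the limit of < 10 nM in this assay, at which 1 of the 4 values shown sits.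

The compounds shown carry only a hydrogen or a methyl at this aromatic carbon, so it remains open what an ethyl group, an amine or a carboxylic acid would do there. It also remains open whether the result for compound 4 would hold on any core beyond the two shown.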